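A few compounds are considered here, and "the series" means these few. Any claim that something is new, unique, unknown or untested is made for them only; others in the source may bear on it.

Three sulfonate esters were tested in a functional assay on MCF7 cells (Homo sapiens) for antiproliferative activity, read by sulforhodamine B assay, with a stated time of 48 h (a higher number here means a weaker inhibitor, a lower number a stronger inhibitor), all carrying the same amide chain on one ring and the same ester on the other. Compound 1 `CC(=O)Nc1cccc(S(=O)(=O)Oc2ccccc2C(C)C)c1` gives 21000 nM. Compound 2 `CCC(=O)Nc1cccc(S(=O)(=O)Oc2ccccc2C(C)C)c1` carries one more carbon on the amide chain, a change counted as methyl in place of hydrogen on a saturated chain carbon bound to a carbonyl carbon, and in this assay compound 2 gives 14000 nM. The step of a 1.5-fold lower number from compound 1 to compound 2 (0.18 log units; within the scatter) shows that lengthening the chain by one carbon at this place did not move the number beyond what repeated runs of this assay would give anyway.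

Compound 3 `CCC(=O)Nc1ccc(S(=O)(=O)Oc2ccccc2C(C)C)cc1` keeps the amide chain of compound 2 but joins it to the core at a different spot; the difference between the two cores is not broken down here. In this assay compound 3 gives 11000 nM, a value that sits close to compound 2 and compound 1, all within the usual scatter of each other.

Compound 4 `CCCC(=O)Nc1ccc(S(=O)(=O)Oc2ccccc2C(C)C)cc1` is compound 3 with one more carbon added to the amide chain, a change counted as methyl in place of hydrogen on a saturated chain carbon, two bonds along the chain from a carbonyl carbon. This is the same kind of change as from compound 1 to compound 2, but not the same: there the new carbon sat on a saturated chain carbon bound to a carbonyl carbon, here it sits two bonds along the chain from a carbonyl carbon. Since the earlier step stayed within the scatter, the step from compound 3 to compound 4 is expected to be about as small, namely a 1.3-fold lower number from compound 3 to compound 4 (0.11 log units; within the scatter), resting on a 1.5-fold lower number from compound 1 to compound 2 (0.18 log units; within the scatter). Compound 4 is therefore estimated to give 8500 nM, with a likely range from 4000 nM to 18000 nM.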

Compound 4, half-maximal inhibitory concentration: 6600 nM
Estimate against measurement, compound 4: 1.3-fold (0.11 log units) above; measured number inside the range.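

Adding one more carbon to the amide chain gives a 1.7-fold lower number from compound 3 to compound 4 (0.22 log units; within the scatter) in this assay and so, taken alone, this step is no larger than the differences seen between repeated runs. Set beside the earlier step, the same kind of change reads alike on the two cores, even though the new carbon sits at a different place along the chain in each pair: the same change on two cores in this assay, a 1.5-fold lower number (0.18 log units; within the scatter) from compound 1 to compound 2 and a 1.7-fold lower number (0.22 log units; within the scatter) from compound 3 to compound 4, 1.1-fold (0.05 log units) apart, within the scatter of two such steps. This agreement shows only that, in these two pairs, one more carbon on the chain made no difference that can be told from the scatter; it does not show that lengthening the chain truly improves activity, and two small steps cannot establish that the change will carry over to any further core in the series.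

The compounds shown leave open whether a longer chain than the propyl of compound 4, or a branched chain, would move the number beyond the scatter on either core. They also leave open whether an amine or a carboxylic acid at the end of the chain would behave any differently from the plain carbon chains seen here.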